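Swapping Bromine for Chlorine on a Weak Growth Inhibitor

The compounds below may be only part of what the source reports. "The series", "measured", "known", "first", "only" and "open" are said of these compounds alone.

Compound 1 has the structure `Clc1ccc(Sc2c(-c3ccc(Br)cc3)[nH]c3ccccc23)cc1`. In a functional assay on Hs 683 cells (Homo sapiens) for inhibition, read by MTT assay, with a stated time of 72 h (a higher number here means a weaker inhibitor of growth, a lower number a stronger inhibitor of growth), compound 1 gives 25000 nM. For the measured compounds named here, only one other compound has been measured, compound 2, with the structure `O=C(CSCc1ccccc1)Nc1c(-c2ccccc2)[nH]c2ccccc12`; in this assay compound 2 gives 33000 nM. Both numbers are large, meaning that neither compound slows the growth of these cells strongly. Compound 1 is the one of the two with the smaller number, but the gap between compound 1 and compound 2 lies within the scatter of repeated measurements, so the two cannot be told apart, and no ranking of them is justified. Compound 2 also has a different core and side chain, so it offers no direct guidance on small changes to compound 1.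

The next compound, compound 3, has the structure `Clc1ccc(Sc2c(-c3ccc(Cl)cc3)[nH]c3ccccc23)cc1`. It is built from compound 1 by a single change: chloro in place of bromo on an aromatic carbon. Bromine and chlorine are both halogens of similar behaviour in such a place, and with only one heavy atom exchanged for another of the same kind, the step from compound 1 to compound 3 in this assay is expected to be small, no change at the digits printed from compound 1 to compound 3 (within the scatter), nothing beyond the scatter in either direction. Compound 3 is therefore estimated at 25000 nM, with a range from 10000 nM to 60000 nM.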

Compound 3, concentration for 50% growth inhibition: 31000 nM
Beside the measured number, compound 3's estimate is 1.2-fold (0.09 log units) below it; the range from low to high includes it.
By their numbers in this assay, from the lowest: compounds 1, 3 and 2 (each within the scatter of the next).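

For the compounds shown here, the step from 4-bromophenyl to 4-chlorophenyl gives the first direct comparison at a single place on compound 1. Going by these compounds alone, until now the only other compound differed in both core and side chain. In this assay the step reads a 1.2-fold higher number from compound 1 to compound 3 (0.09 log units; within the scatter) and so can be read on its own. At this place, on an aromatic carbon para to a large group, bromo and chloro therefore cannot be told apart, and this exchange of one halogen for the other offers no measurable gain in growth inhibition for the series. Nothing available speaks to why the two halogens read alike here.

The compounds shown leave open how a group of a different kind at this same place, such as an amine, a carboxylic acid or a longer chain, would read, and whether any of them would move the number beyond the scatter. They also leave open whether a change elsewhere on compound 1, for instance to the sulfur link or to the other chloro group, would matter more than this one did.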